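A few compounds are considered here, and "the series" means these few. Any claim that something is new, unique, unknown or untested is made for them only; others in the source may bear on it.

Among the compounds with values here, the three compounds measured so far share one core and differ only at the far end of the chain. In a functional assay for inhibition of Polyunsaturated fatty acid 5-lipoxygenase (Homo sapiens) (a higher number here means that more compound is needed for the effect, a lower number that less compound is needed), compound 1 `CN(O)C(=O)CCSc1nc2ccccc2s1` gives 39 nM. Compound 2 `CN(O)C(=O)NCCSc1nc2ccccc2s1` gives 90 nM in this assay, and compound 3 `O=C(NO)NCCSc1nc2ccccc2s1` gives 5200 nM. Compound 2 therefore stands second of the three: the number rises a 2.3-fold higher number from compound 1 to compound 2 (0.36 log units; beyond the scatter), and it rises much further a 58-fold higher number from compound 2 to compound 3 (1.76 log units; beyond the scatter). Compound 4 `CN(O)C(=O)NCCSc1nc2cccc(Cl)c2s1` keeps the whole chain end of compound 2 and changes only the ring: chloro in place of hydrogen on an aromatic carbon. Within the data shown here, every measured step alters the group at the end of the chain, and none alters the ring, so no measured step bears directly on this change. The data give no direction for it, and a step within the usual scatter is expected, no change at the digits printed from compound 2 to compound 4 (within the scatter). Compound 4 is estimated at 90 nM in this assay, with a range from 30 nM to 270 nM.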

Compound 4, half-maximal effective concentration: 530 nM
The estimate for compound 4 lay 5.9-fold (0.77 log units) below the measured number, and the stated range ends below it.
By their numbers in this assay, from the lowest: compound 1; then compound 2; then compound 4; then compound 3.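

The ring of the shared core turns out not to be a silent part of these molecules: in this assay, chloro in place of hydrogen on an aromatic carbon, ortho to a fused ring and meta to a fused ring, gives a 5.9-fold higher number from compound 2 to compound 4 (0.77 log units; beyond the scatter) with the chain end left unchanged. This modest step is still smaller than the large one at the chain end, a 58-fold higher number from compound 2 to compound 3 (1.76 log units; beyond the scatter), so in this series losing that methyl costs more than adding this chloro. Nothing available here accounts for the rise in the number from this chloro.

Going by these compounds, whether any group at this carbon raises the number, or chloro in particular, remains open; a fluoro, methyl or methoxy group there would help to tell. Also open, on these data alone, is whether chloro on another carbon of this ring would give a similar step.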